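The source may report more compounds than this note shows. Statements on the series, on what has been measured and on what is new or still open speak of the compounds shown alone.

Measured so far:
Compound 1 `O=C(Nc1ccccn1)c1cccc(Nc2ncc(F)c(Nc3ccc(F)cc3)n2)c1`: 15300 nM
Compound 2 `O=C(Nc1cccc(Nc2ncc(F)c(Nc3ccc(F)cc3)n2)c1)c1cnccn1`: 10300 nM

Among the compounds with values here, in a functional assay on A549 cells (Homo sapiens) for antiproliferative activity, read by sulforhodamine B assay, with a stated time of 3 days (on this read-out higher numbers stand for weaker inhibition of growth and lower numbers for stronger inhibition of growth), compound 2 gives 10300 nM, which lies within the scatter of compound 1, the only other compound measured. Compound 3 `CN1CCC(C(=O)Nc2cccc(Nc3ncc(F)c(Nc4ccc(F)cc4)n3)c2)CC1` carries 1-methylpiperidin-4-yl in place of pyrazin-2-yl on a carbonyl carbon. Within the data shown here, only one measured step bears on this change: a 1.5-fold lower number from compound 1 to compound 2 (0.17 log units; within the scatter). That small step exchanged (pyridin-2-yl)carbamoyl for ((pyrazin-2-yl)carbonyl)amino. Among the measured compounds shown here, no measured compound carries a non-aromatic ring on that carbonyl, so the guide is weak and the range must stay wide. No step beyond the scatter is expected in this assay, and the estimate is a 1.3-fold lower number from compound 2 to compound 3 (0.11 log units; within the scatter). Compound 3 is expected at 8000 nM, with an estimated range of 2500 nM to 25000 nM.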

Compound 3, concentration for 50% growth inhibition: 1330 nM
Compound 3: the middle estimate sits 6.0-fold (0.78 log units) above what was measured; measured number below the stated range.
By their numbers in this assay, from the lowest: compound 3; then compounds 2 and 1 (each within the scatter of the next).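

In this assay, within the data shown here, 1-methylpiperidin-4-yl in place of pyrazin-2-yl on a carbonyl carbon gives a 7.7-fold lower number from compound 2 to compound 3 (0.89 log units; beyond the scatter) and shows that the group on this carbonyl can change the read-out, which the only earlier step, within the scatter, did not show. The wider exchange of (pyridin-2-yl)carbamoyl for ((1-methylpiperidin-4-yl)carbonyl)amino on an aromatic carbon gives a 12-fold lower number from compound 1 to compound 3 (1.06 log units; beyond the scatter) and places the one non-aromatic ring shown ahead of both aromatic rings, though a single compound sets no rule. Nothing measured here explains why this change has such an effect.

Open, from the compounds shown here alone, is whether the ring nitrogen is needed at all, which a cyclohexyl group on the same carbonyl would test. Also open, going by these compounds, is what piperidin-4-yl without its methyl group, or an open-chain dimethylaminomethyl group, would give at this position.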